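This account rests on a few compounds, and the source may have more. Where it says the series, first, only, none or still open, it means among the compounds named here.

Measured compounds:
compound 1 `COc1ccc(S(=O)(=O)N2CCc3cccc(-c4cccnc4)c32)cc1`: 76.3 nM
compound 2 `COc1ccc(S(=O)(=O)N2CCc3cccc(-c4ccc(F)c(F)c4)c32)cc1`: 57 nM
compound 3 `COc1ccc(-c2cccc3c2N(S(=O)(=O)c2ccc(OC)cc2)CC3)cc1`: 277 nM

In a functional assay on HT-29 cells (Homo sapiens) for inhibition, with a stated time of 72 h (on this read-out lower numbers stand for stronger inhibition and higher numbers for weaker inhibition), compound 3 gives the highest of the three numbers. Its nearest neighbour is compound 1, and a 3.6-fold higher number from compound 1 to compound 3 (0.56 log units; beyond the scatter) and a 4.9-fold higher number from compound 2 to compound 3 (0.69 log units; beyond the scatter) both set compound 3 apart, whereas compound 1 and compound 2 sit within the scatter of each other (a 1.3-fold lower number from compound 1 to compound 2 (0.13 log units; within the scatter)). Compound 4 `COc1ccc(S(=O)(=O)N2CCc3cccc(-c4cccs4)c32)cc1` is not yet measured; it differs from compound 3 by thiophen-2-yl in place of 4-methoxyphenyl on an aromatic carbon. Both measured steps that bring 4-methoxyphenyl onto this aromatic carbon raise the number, so replacing it by thiophen-2-yl is expected to reverse part of that in this assay, a downward step of about a 3.1-fold lower number from compound 3 to compound 4 (0.49 log units; beyond the scatter). The estimate for compound 4 is 90 nM, with a range from 40 nM to 220 nM.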

Compound 4, half-maximal inhibitory concentration: 200 nM
Compound 4: the middle estimate sits 2.2-fold (0.35 log units) below what was measured; the range from low to high includes it.
By their numbers in this assay, from the lowest: compounds 2 and 1 (each within the scatter of the next); then compounds 4 and 3 (each within the scatter of the next).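

In this assay, thiophen-2-yl on this aromatic carbon does not separate from 4-methoxyphenyl: a 1.4-fold lower number from compound 3 to compound 4 (0.14 log units; within the scatter) and this step stays within the scatter. Against the other two groups the picture differs, with a 2.6-fold higher number from compound 1 to compound 4 (0.42 log units; beyond the scatter) and a 3.5-fold higher number from compound 2 to compound 4 (0.55 log units; beyond the scatter) both beyond the scatter. Ring size therefore does not sort this position, since the six-membered 4-methoxyphenyl stands with the five-membered thiophen-2-yl and apart from the six-membered pyridin-3-yl and 3,4-difluorophenyl.

Open, as far as these compounds go, is how a morpholine, a carboxylic acid or a longer alkyl chain would read at this carbon. From the compounds shown here alone, what divides the two pairs also stays open, as no measured evidence bears on it.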